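Fluoro for methoxy on the phenyl ring of compound 2

The source may hold more compounds than are shown below. What is called first, only, known or untested is meant among the compounds shown, and "the series" means these compounds.

Measured so far:
compound 1, `O=Cc1ccc(-c2cn3ccnc3c(-c3ccc4ncn(C5CCCCC5)c4c3)n2)cc1`, 58.7%
compound 2, `COc1ccccc1-c1cn2ccnc2c(-c2ccc3ncn(C4CCCCC4)c3c2)n1`, 22.4%

Both compounds share one core and differ only in the group attached to the phenyl ring. In a functional assay on MOLT-4 cells (Homo sapiens) for inhibition, read by sulforhodamine B assay, with a stated time of 48 h, tested at 10 uM (a higher number here means more inhibition at the concentration tested (going by the name of the read-out), a lower number less inhibition), compound 1 gives 58.7%, while compound 2 gives 22.4%. Compound 2 therefore stands at the lower of the two numbers, and the step of a number 36.3 percentage points lower from compound 1 to compound 2 (beyond the scatter) shows that swapping the group on this ring can move the read-out by a good deal.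

Compound 3, `Fc1ccccc1-c1cn2ccnc2c(-c2ccc3ncn(C4CCCCC4)c3c2)n1`, is not yet measured. It differs from compound 2 in one place: fluoro in place of methoxy on an aromatic carbon.

For the measured compounds named here, no measured step has this same exchange, so no direct guide exists. Going by the values given here, the only step at hand, from compound 1 to compound 2, changes a different group and only shows that the read-out is sensitive to what sits on this ring. Compound 3 is therefore expected to stay near compound 2, with a step of a number 7.6 percentage points higher from compound 2 to compound 3 (within the scatter) in this assay that may fall either way. The estimate for compound 3 is 30%, within a range from 8% to 55%.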

Compound 3, a percentage reported as inhibition, at one concentration (the size of the read-out at that concentration, not a potency): 22.5%
Beside the measured number, compound 3's estimate is 7.5 percentage points above it; the measured number falls inside the stated range.
By their numbers in this assay, from the lowest: compounds 2 and 3 (each within the scatter of the next); then compound 1.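

In this assay, putting fluoro in place of methoxy on the ring carbon ortho to a large group gives a number 0.1 percentage points higher from compound 2 to compound 3 (within the scatter), so at this place the two groups cannot be told apart. The earlier compounds shown here showed only that 2-methoxyphenyl reads far lower than 4-formylphenyl, and the new comparison gives a number 36.2 percentage points lower from compound 1 to compound 3 (beyond the scatter), which shows that this large gap also appears with 2-fluorophenyl and does not depend on methoxy alone. Nothing available explains why methoxy and fluoro read alike here.

From the compounds shown here alone, both comparisons with compound 1 change the group and its place on the ring together, so it stays open whether the formyl group or its position matters, and a pair such as 2-formylphenyl and 4-fluorophenyl would begin to separate the two. It also stays open whether any group at this ortho place can restore the higher reading, for example an amine or a carboxylic acid, since methoxy and fluoro are the only two groups shown there.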